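A few compounds are considered here, and "the series" means these few. Any claim that something is new, unique, unknown or untested is made for them only; others in the source may bear on it.

Three compounds of the series carry numbers in an assay on isolated protein for inhibition of Indoleamine 2,3-dioxygenase 1 (Homo sapiens), read by fluorescence, with a stated time of 60 min; a higher number here means a weaker inhibitor, a lower number a stronger inhibitor. Compound 1 `N=S1(=O)CC(Nc2nonc2/C(=N/O)Nc2ccc(F)c(Br)c2)C1` gives 208 nM. Compound 2 `O=S(=O)(CCNc1nonc1/C(=N/O)Nc1ccc(F)c(Br)c1)N1CCC1` gives 191 nM, the step being a 1.1-fold lower number from compound 1 to compound 2 (0.04 log units; within the scatter). Compound 3 `CCNS(=O)(=O)CCNc1nonc1/C(=N/O)Nc1ccc(F)c(Br)c1` gives 95 nM, reached by a 2.2-fold lower number from compound 1 to compound 3 (0.34 log units; beyond the scatter). Compound 3 thus holds the lowest of the three numbers as read, with the gap to compound 2 within the scatter and only the gap to compound 1 beyond it.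

Compound 4 `C#CCNS(=O)(=O)CCNc1nonc1/C(=N/O)Nc1ccc(F)c(Br)c1` is still to be measured in this assay. It differs from compound 3 by ethynyl in place of methyl on a saturated chain carbon bound to a sulfonamide nitrogen. Among the measured compounds shown here, no measured step touches this chain carbon; the closest comparison is the exchange on the sulfonyl sulfur, a 2.0-fold lower number from compound 2 to compound 3 (0.30 log units; within the scatter), and the wider replacements of the whole side chain, both of which moved the number little. A short extension at the end of the side chain is therefore expected to give no step beyond the scatter, a 1.1-fold lower number from compound 3 to compound 4 (0.02 log units; within the scatter). Compound 4 is estimated at 90 nM, with a range of 45 nM to 180 nM.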

Compound 4, half-maximal inhibitory concentration: 218 nM
Compound 4: the middle estimate sits 2.4-fold (0.38 log units) below what was measured; the whole stated range lies below it.
By their numbers in this assay, from the lowest: compounds 3, 2, 1 and 4 (each within the scatter of the next, the first and the last beyond it).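

In this assay, the chain carbon on the sulfonamide nitrogen is sensitive to change: ethynyl in place of methyl, read as ethyl to propargyl, gives a modest step beyond the scatter (a 2.3-fold higher number from compound 3 to compound 4 (0.36 log units; beyond the scatter)). The separation of compound 3 from compound 1 is not kept with propargylamino on the sulfonyl sulfur, as the steps to compound 4 from the other two compounds both lie within the scatter (a 1.1-fold higher number from compound 2 to compound 4 (0.06 log units; within the scatter)) and (a 1.0-fold higher number from compound 1 to compound 4 (0.02 log units; within the scatter)). Nothing available bears on the origin of the step from ethyl to propargyl.

A propyl group on the sulfonamide nitrogen would separate the longer chain from the triple bond. Going by these compounds, how a methyl group or a longer butyl chain at this nitrogen would read remains open.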